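Shortening a hydroxyalkyl chain on a myosin-2 inhibitor

The source may hold more compounds than are shown below. What is called first, only, known or untested is meant among the compounds shown, and "the series" means these compounds.

Compound 1 `C/C(=N\CCCO)c1c(O)c2ccccc2oc1=O` was tested in an assay on isolated protein for inhibition of myosin-2 (Bos taurus), read by spectrophotometry, with a stated time of 24 min (on this read-out higher numbers stand for weaker inhibition and lower numbers for stronger inhibition), and gives 37000 nM. Among the three results in hand, compound 1 is the only one reported as a number. Compound 2 `CCCC/N=C(\C)c1c(O)c2ccccc2[nH]c1=O` in this assay gives >= 100000 nM, which is a limit of the assay rather than a measured number. Compound 3 `C/C(=N\Cc1ccccc1)c1c(O)c2ccccc2n(C)c1=O` in this assay likewise returns a limit of >= 100000 nM. Among the measured compounds shown here, both of those results sit at the limit of >= 100000 nM in this assay, at which 2 of the 3 values shown sit, so no step between two measured compounds can be sized here. Compound 4 `C/C(=N\CCO)c1c(O)c2ccccc2oc1=O` has not yet been measured. It differs from compound 1 in one place: hydroxy in place of hydroxymethyl on a saturated chain carbon, two bonds along the chain from a double-bonded nitrogen. Read one bond further out, the change is 3-hydroxypropyl to 2-hydroxyethyl. For the measured compounds named here, with no measured step to lean on, the expected step from compound 1 to compound 4 in this assay is small, a 1.2-fold higher number from compound 1 to compound 4 (0.09 log units; within the scatter), and may well fall within the usual scatter. Compound 4 is therefore estimated to give 45000 nM in this assay, within a range from 15000 nM to 130000 nM.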

Compound 4, half-maximal inhibitory concentration: 92000 nM
Compound 4: middle estimate off by 2.0-fold (0.31 log units), on the low side, within the range that was stated.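

Among the compounds shown here, this is the first step in the set that can be sized: in this assay, shortening the chain from 3-hydroxypropyl to 2-hydroxyethyl gives a 2.5-fold higher number from compound 1 to compound 4 (0.40 log units; beyond the scatter). Losing one carbon while keeping the hydroxy therefore weakens inhibition by a modest amount, but by more than the usual scatter, so chain length matters at this position. It also leaves compound 4 not far short of where this read-out stops giving numbers: the limit of >= 100000 nM in this assay, at which 2 of the 4 values shown sit.

This single pair cannot establish a trend, and steps involving compound 2 or compound 3 cannot be read. As far as these compounds go, whether a longer chain such as 4-hydroxybutyl would strengthen inhibition further, or how an amine would compare with the hydroxy on the same chain, remains open.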